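A few compounds are considered here, and "the series" means these few. Any claim that something is new, unique, unknown or untested is made for them only; others in the source may bear on it.

Measured so far in a physicochemical assay for solubility, in phosphate buffer, with a stated time of 18 h; a higher number here means a more soluble compound, a lower number a less soluble compound:
- compound 1 `N#Cc1c(N)nc2nc(C3CCCC3)ncc2c1N`: 89000 nM
- compound 2 `CSc1nc(C(C)(C)C)nc2nc(N)c(C#N)c(N)c12`: 14000 nM

Compound 2 holds the lower of the two numbers, and its gap to compound 1 lies beyond the scatter. The next compound is compound 3 `CC(C)(C)c1nc(C2CCCC2)c2c(N)c(C#N)c(N)nc2n1`, not yet measured. Compared with compound 2, it has cyclopentyl in place of methylsulfanyl on an aromatic carbon.

Going by the values given here, no measured pair differs in one place only, so this assay offers no direct step for this change. Compound 1 also carries cyclopentyl, but it differs from compound 2 in more than one place. The expectation therefore rests on the structural change, a larger all-carbon group replacing a smaller one, starting from compound 2 at 14000 nM. The expected change is a moderate fall beyond the scatter, a 2.8-fold lower number from compound 2 to compound 3 (0.45 log units; beyond the scatter). The estimated value for compound 3 is 5000 nM, expected within 1200 nM to 20000 nM.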

Compound 3, solubility: < 1000 nM
Compound 3: a limit, no number; the forecaster's own chance of this, stated with the estimate: 10%; middle value at least 5.0-fold (0.69 log units) from the limit.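

In this assay, compound 3 stands at < 1000 nM, which is a limit of the assay and not a number. This gives the series its first comparison in one place: cyclopentyl in place of methylsulfanyl on an aromatic carbon, next to the ring nitrogen and meta to a tert-butyl group, gives an at least 14-fold lower number from compound 2 to compound 3 (1.14 log units; beyond the scatter), a large step at this position. The full size of that step stays unknown, since one end of it is only a limit: the limit of < 1000 nM in this assay, at which 1 of the 3 values shown sits.

The swap changes the heavy-atom count, adds a ring and removes the sulfur all at once, so the compounds shown do not separate these three changes. On these data alone, whether an amine such as morpholine or a small methoxy group at this carbon would keep the value of compound 2 remains open.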